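The source may report more compounds than this note shows. Statements on the series, on what has been measured and on what is new or still open speak of the compounds shown alone.

Of the compounds shown here, three built on one shared core have so far been tested in an ADME assay on HEL cells (Homo sapiens) for cytotoxicity; on this read-out higher numbers stand for lower toxicity in this test and lower numbers for higher toxicity in this test. Compound 1 `C/C(=N\NC(=O)COc1cccc2ccccc12)c1ccc(C#N)cc1Br` gives 20 ug/mL in this assay. Compound 3 `O=C(COc1cccc2ccccc12)N/N=C/c1ccc(O)cc1` gives 20 ug/mL in this assay, which stands level with compound 1 at the digits shown and within the scatter, so no order between the two can be read. Compound 2 `COc1cc(/C=N/NC(=O)COc2cccc3ccccc23)cc(OC)c1OC` reports in this assay only a limit, >= 20 ug/mL, and not a number. This is the limit of >= 20 ug/mL in this assay, at which 1 of the 3 values shown sits.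

Compound 4 `O=C(COc1cccc2ccccc12)N/N=C/c1cccc(Br)c1` has not yet been measured in this assay. It differs from compound 3 in one place: 3-bromophenyl in place of 4-hydroxyphenyl on a carbon with a double bond to nitrogen. Among the measured compounds no pair differs in a single place, so the numbers give no step that shows how such a swap moves this read-out. The step of no change at the digits printed from compound 3 to compound 4 (within the scatter) is expected to stay within the scatter, with no direction favoured. Compound 4 is estimated at 20 ug/mL in this assay, with a range from 10 ug/mL to 40 ug/mL.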

Compound 4, minimum cytotoxic concentration: 100 ug/mL
For compound 4 the middle estimate is 5.0-fold (0.70 log units) below the measured one; the whole stated range lies below it.
By their numbers in this assay, from the lowest: compounds 1 and 3 (each within the scatter of the next); then compound 4.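

Going by these compounds alone, the swap of 4-hydroxyphenyl for 3-bromophenyl on a carbon with a double bond to nitrogen in this assay gives a 5.0-fold higher number from compound 3 to compound 4 (0.70 log units; beyond the scatter) and is the first change in one place that can be read here. It shows that the group at this position can move the read-out beyond the scatter, here toward lower toxicity in this test. Nothing measured here bears on why the number moves.

The step changes the ring place and the group on the ring together, so 3-hydroxyphenyl and 4-bromophenyl at this position would be needed to tell these two changes apart. Going by these compounds, it also remains open how other groups on the ring at this position, such as an amine in 3-aminophenyl or a carboxylic acid in 3-carboxyphenyl, would shift the read-out.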